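The source may report more compounds than this note shows. Statements on the series, on what has been measured and on what is new or still open speak of the compounds shown alone.

Measured compounds:
- Compound 1, `COc1ccc([C@@H]2CC(=O)c3c(O)cc(OCc4cn(C5CCCC5)nn4)cc3O2)cc1O`: in a functional assay on RAW264.7 cells (Mus musculus) for inhibition, read by Griess assay, with stated times of 2 h and 24 h (on this read-out lower numbers stand for stronger inhibition and higher numbers for weaker inhibition), compound 1 gives 10500 nM.
- Compound 2, `CCn1cc(COc2cc(O)c3c(c2)O[C@H](c2ccc(OC)c(O)c2)C/C3=N\O)nn1`: in this assay compound 2 gives 3140 nM.
- Compound 3, `COc1ccc([C@@H]2CC(=O)c3c(O)cc(OCc4cn(Cc5cccc(Cl)c5)nn4)cc3O2)cc1O`: in this assay compound 3 gives 18200 nM.

Compound 2 stands lowest of the three numbers in this assay; compound 1 is the nearest, with a higher number beyond the scatter, and compound 3 the furthest, also beyond the scatter. Compound 4, `CCCn1cc(COc2cc(O)c3c(c2)O[C@H](c2ccc(OC)c(O)c2)C/C3=N\O)nn1`, differs from compound 2 in one place: methyl in place of hydrogen on a saturated chain carbon, two bonds along the chain from an aromatic nitrogen.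

Among the compounds with values here, the only measured single-point step, a 1.7-fold higher number from compound 1 to compound 3 (0.24 log units; within the scatter), swaps one substituent on the aromatic nitrogen for another within the ketone series and stays within the scatter. It bears on the present change only loosely: it involves a ring-to-ring exchange, not a lengthening of a chain, and it sits in the ketone series rather than the oxime series of compound 2. Within the data shown here, no measured pair shows a chain grown by one carbon on that nitrogen. Among the measured compounds shown here, with the one relevant step flat, the expected step from compound 2 to compound 4 in this assay is none beyond the scatter, a 1.0-fold higher number from compound 2 to compound 4 (0.01 log units; within the scatter), in either direction.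

For compound 4 the estimated value in this assay is 3200 nM, with an expected range from 1300 nM to 8000 nM.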

Compound 4, half-maximal inhibitory concentration: 2340 nM
The estimate for compound 4 lay 1.4-fold (0.14 log units) above the measured number; the measured number falls inside the stated range.
By their numbers in this assay, from the lowest: compounds 4 and 2 (each within the scatter of the next); then compounds 1 and 3 (each within the scatter of the next).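

In this assay, extending 1-ethyl-1H-1,2,3-triazol-4-yl to 1-propyl-1H-1,2,3-triazol-4-yl gives a 1.3-fold lower number from compound 2 to compound 4 (0.13 log units; within the scatter), so adding methyl on the saturated chain carbon, two bonds along the chain from an aromatic nitrogen, does not separate the two compounds on this read-out. The earlier compounds shown here offered only a ring-to-ring exchange on that nitrogen in the ketone series, a 1.7-fold higher number from compound 1 to compound 3 (0.24 log units; within the scatter); this pair adds a chain extension in the oxime series, and both single-place steps at this substituent now lie within the scatter, although that rests on just these two pairs. No available evidence accounts for the flat step.

Going by these compounds, whether the tolerance persists with a longer chain such as butyl or hexyl, or with an amine or a carboxylic acid at the end of the propyl chain, remains open. Compound 1 and compound 2 differ in more than one place, so the contribution of the oxime relative to the ketone also remains unresolved, and a ketone and oxime pair carrying the same nitrogen substituent would be needed to isolate it.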